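Piperidin-1-yl in place of pyrrolidin-1-yl on compound 2

The source may hold more compounds than are shown below. What is called first, only, known or untested is meant among the compounds shown, and "the series" means these compounds.

In an ADME assay on L6 cells (Rattus norvegicus) for cytotoxicity, read by resazurin assay, with a stated time of 72 h (a higher number here means a weaker inhibitor, a lower number a stronger inhibitor), compound 2 (`CN(C)C12CC(OC(=O)CN3CCCC3)C(C(c3ccccc3)C1)C(c1ccccc1)C2`) gives 32700 nM. Compound 1 (`NC1CC2(N3CCCC3)CC(c3ccccc3)C1C(c1ccccc1)C2`) gives 38100 nM, and compound 3 (`NCC(=O)OC1CC2(N3CCCC3)CC(c3ccccc3)C1C(c1ccccc1)C2`) gives 42900 nM. Compound 2 therefore lies within the usual scatter of both other measured compounds, and the three numbers cannot be ranked.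

Compound 4 (`CN(C)C12CC(OC(=O)CN3CCCCC3)C(C(c3ccccc3)C1)C(c1ccccc1)C2`) carries piperidin-1-yl in place of pyrrolidin-1-yl on a saturated chain carbon bound to a carbonyl carbon. For the measured compounds named here, no measured pair shows this exchange directly. Going by the values given here, the only measured step, a 1.1-fold higher number from compound 1 to compound 3 (0.05 log units; within the scatter), is a different change at a different place, and it stayed within the scatter. It offers only indirect guidance, but it gives no sign that a change to these side groups moves the number much in this assay. No shift beyond the scatter is therefore expected, in either direction. The estimated move is a 1.1-fold lower number from compound 2 to compound 4 (0.04 log units; within the scatter). For compound 4 the expected value is 30000 nM, with an estimated range of 14000 nM to 60000 nM.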

Compound 4, half-maximal inhibitory concentration: 29300 nM
For compound 4 the middle estimate is 1.0-fold (0.01 log units) above the measured one; measured number inside the range.
By their numbers in this assay, from the lowest: compounds 4, 2, 1 and 3 (each within the scatter of the next).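

In this assay, putting the six-membered piperidin-1-yl in place of the five-membered pyrrolidin-1-yl gives a 1.1-fold lower number from compound 2 to compound 4 (0.05 log units; within the scatter) and so offers the only direct reading of this exchange among the compounds shown. For the compounds shown here, on a saturated chain carbon bound to a carbonyl carbon, these two rings cannot be told apart by this read-out, which the earlier compounds could only hint at through a different change at a different place. Nothing available explains this result.

From the compounds shown here alone, whether morpholin-4-yl, an open-chain amine or a carboxylic acid on the same chain carbon would give a number beyond the scatter remains open. So does the effect of a longer chain carrying the piperidin-1-yl ring, and whether this exchange would read the same way on a different core.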